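The compounds below may be only part of what the source reports. "The series", "measured", "known", "first", "only" and "open" are said of these compounds alone.

Measured so far in a functional assay on A-375 cells (Homo sapiens) for antiproliferative activity, read by MTT assay, with a stated time of 72 h; on this read-out lower numbers stand for stronger inhibition and higher numbers for weaker inhibition:

compound 1 `COc1ncc(-c2ccc3c(c2)N(c2ccc(C)cc2)C(=O)CO3)cc1NS(=O)(=O)c1ccc(F)cc1`: 12900 nM
compound 2 `COc1ncc(-c2ccc3c(c2)N(C2CCCCC2)C(=O)CO3)cc1NS(=O)(=O)c1ccc(F)cc1`: > 40000 nM, a limit of the assay
compound 3 `O=C1COc2ccc(-c3cnc4ccccc4c3)cc2N1C1CCCCC1`: > 40000 nM, a limit of the assay

Compound 1 and compound 2 share one core and differ in a single place, (4-methylphenyl in place of cyclohexyl on an amide-type nitrogen in a ring). In this assay this gives an at least 3.1-fold lower number from compound 2 to compound 1 (0.49 log units; beyond the scatter). Compound 2 returns only a limit, so the true size of that step is open upward. Two of the three values sit at the same limit (the limit of > 40000 nM in this assay, at which 2 of the 3 values shown sit).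

Compound 3 carries a different core; the difference between the two cores is not broken down here. Compound 4 `Cc1ccc(N2C(=O)COc3ccc(-c4cnc5ccccc5c4)cc32)cc1` is compound 3 with 4-methylphenyl in place of cyclohexyl on an amide-type nitrogen in a ring, the same change as that between compound 2 and compound 1, at a place described in identical terms.

Compound 3 returns only a limit in this assay, so the starting point for compound 4 is itself uncertain. Carrying over the size of an at least 3.1-fold lower number from compound 2 to compound 1 (0.49 log units; beyond the scatter), the expected step is an at least 2.0-fold lower number from compound 3 to compound 4 (0.30 log units; that floor lies within the scatter). Compound 4 is therefore estimated at 20000 nM, within 7000 nM to 60000 nM, with a real chance that the assay again reports only a limit.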

Compound 4, half-maximal inhibitory concentration: > 40000 nM
Compound 4 gave a limit, no number; the forecaster's own chance of this, stated with the estimate: 40%; middle value at least 2.0-fold (0.30 log units) from the limit.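

In this assay compound 4 gives > 40000 nM, a limit of the assay. Compound 3 sits at the same limit, so no step can be read between compound 3 and compound 4: the limit of > 40000 nM in this assay, at which 3 of the 4 values shown sit.

Still open, from the compounds shown here alone, is whether 4-methylphenyl in place of cyclohexyl changes the read-out at all on the core of compound 3.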